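The compounds below may be only part of what the source reports. "The series", "measured", "known", "first", "only" and "open" are said of these compounds alone.

Measured compounds:
compound 1 `COC(=O)C1=C(C)NC(C)=C(C(=O)OC)C1c1cccc(OCC(=O)N2CCN(C)CC2)c1` gives 10000 nM
compound 2 `COC(=O)C1=C(C)NC(C)=C(C(=O)OC)C1c1cccc(OCC(=O)N2CCOCC2)c1` gives 9900 nM
compound 3 `COC(=O)COc1ccc(C2C(C(=O)OC)=C(C)NC(C)=C2C(=O)OC)cc1` gives 2100 nM

All three were tested in an assay on cells for inhibition of Voltage-gated L-type calcium channel (Rattus norvegicus), read by fluorescence and calcium flux, with stated times of 30 min and 2 min; on this read-out lower numbers stand for stronger inhibition and higher numbers for weaker inhibition. Among these, compound 2 stands second highest of the three numbers; its nearest neighbour is compound 1, and the step of a 1.0-fold lower number from compound 1 to compound 2 (0.00 log units; within the scatter) lies within the scatter, so the two cannot be told apart. Compound 3, which also carries a (methoxycarbonyl)methoxy group, stands furthest from compound 2, with a number beyond the scatter lower.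

The next compound, compound 4 `COC(=O)COc1cccc(C2C(C(=O)OC)=C(C)NC(C)=C2C(=O)OC)c1`, is derived from compound 2 by a single change: methoxy in place of morpholin-4-yl on a carbonyl carbon.

Among the compounds with values here, no measured step covers exactly this change. Within the data shown here, the only measured step, from compound 1 to compound 2, swaps one ring-shaped group for another on the carbonyl carbon and shows nothing beyond the scatter. Among the measured compounds shown here, the shift from a six-atom ring to a two-atom methoxy is a larger change than that, and compound 3, the one measured compound bearing the same methoxycarbonyl group, gives 2100 nM, a lower number than compound 2. A modest step toward a lower number is therefore expected, a 2.8-fold lower number from compound 2 to compound 4 (0.45 log units; beyond the scatter), though the evidence for it is indirect.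

On that basis compound 4 is estimated at 3500 nM, with a likely range from 1200 nM to 10000 nM.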

Compound 4, half-maximal inhibitory concentration: 10000 nM
Estimate against measurement, compound 4: 2.9-fold (0.46 log units) below; measured number inside the range.
By their numbers in this assay, from the lowest: compound 3; then compounds 2, 1 and 4 (each within the scatter of the next).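

In this assay the carbonyl carbon shows no response to a much larger change than the earlier swap of one ring for another: replacing the morpholin-4-yl ring with methoxy, which turns an amide into an ester and removes the ring, gives (a 1.0-fold higher number from compound 2 to compound 4 (0.00 log units; within the scatter)), and replacing 4-methylpiperazin-1-yl with methoxy gives (no change at the digits printed from compound 1 to compound 4 (within the scatter)), so these three groups cannot be told apart here. The methoxycarbonyl end therefore does not by itself bring the lower number seen for compound 3 (2100 nM), since compound 4 carries the same (methoxycarbonyl)methoxy group and gives (10000 nM), and the two differ only in where that group sits on the shared core. No measurement shown offers an explanation for this lack of response.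

Going by these compounds, it remains open whether a carboxylic acid, a simple open-chain amine or a longer chain on the same carbonyl carbon would move the number beyond the scatter. On these data alone, it is also open whether the morpholin-4-yl or 4-methylpiperazin-1-yl amide would match compound 3 when attached where compound 3 carries its group.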